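This account rests on a few compounds, and the source may have more. Where it says the series, first, only, none or still open, it means among the compounds named here.

Compound 2 `Cc1cc(-c2ccccc2)n(/C(N)=N/S(=O)(=O)c2cc(C)c(Cl)cc2SCc2ccc(Cl)cc2)n1` and compound 1 `Cc1cc(-c2ccccc2)n(/C(N)=N/S(=O)(=O)c2cc(C)c(Cl)cc2SCc2ccc(C(F)(F)F)cc2)n1` share one core and differ by trifluoromethyl in place of chloro on an aromatic carbon. In an ADME assay on microsomes from liver (Homo sapiens) for metabolic stability, read by LC-MS, using NADPH, tested at 5 uM (on this read-out higher numbers stand for a longer-lived compound and lower numbers for a shorter-lived compound), compound 2 gives 0.24 h, while compound 1 gives 0.241 h, so that a 1.0-fold higher number from compound 2 to compound 1 (0.00 log units; within the scatter). Compound 3 `Cc1cc(S(=O)(=O)/N=C(\N)n2nccc2-c2ccccc2)c(SCc2ccccc2Cl)cc1Cl` carries a core whose difference from the core of compound 2 is not broken down here; in this assay compound 3 gives 0.226 h, a number within the scatter of the other two. Compound 4 `Cc1cc(S(=O)(=O)/N=C(\N)n2nccc2-c2ccccc2)c(SCc2ccccc2C(F)(F)F)cc1Cl` differs from compound 3 by trifluoromethyl in place of chloro on an aromatic carbon. This is the same kind of change as that from compound 2 to compound 1, though the place is not identical: there the group sat para to a large group, here it sits ortho to a large group. Because a 1.0-fold higher number from compound 2 to compound 1 (0.00 log units; within the scatter) lay within the scatter, a step of similar size is expected, namely a 1.0-fold higher number from compound 3 to compound 4 (0.01 log units; within the scatter). Compound 4 is therefore estimated to give 0.23 h, most likely between 0.12 h and 0.45 h.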

Compound 4, half-life: 0.15 h
Compound 4: middle estimate off by 1.5-fold (0.19 log units), on the high side; the measured number falls inside the stated range.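

Trifluoromethyl in place of chloro on an aromatic carbon gives a 1.5-fold lower number from compound 3 to compound 4 (0.18 log units; within the scatter) in this assay. Set beside the earlier case, the two steps do not separate: the same change on two cores in this assay, a 1.0-fold higher number (0.00 log units; within the scatter) from compound 2 to compound 1 and a 1.5-fold lower number (0.18 log units; within the scatter) from compound 3 to compound 4, 1.5-fold (0.18 log units) apart, within the scatter of two such steps. On these two cores, the change can therefore be carried across without either step leaving the scatter, but two pairs do not show that it would behave the same way on other cores or at other places on the ring.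

The compounds shown leave open whether a nitrile, a methoxy group or a carboxylic acid in the same place would give a half-life outside the scatter of these numbers. They also leave open what an ether or an amine in place of the sulfanyl link would do.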